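The source may report more compounds than this note shows. Statements on the series, on what has been measured and on what is new or still open speak of the compounds shown alone.

Measured so far:
compound 1 `Cc1ccc(-n2ccnc2SCC(=O)Nc2ccc(C)cc2Br)cc1` gives 80800 nM in an ADME assay on MT4 cells (Homo sapiens) for cytotoxicity, read by MTT assay; on this read-out higher numbers stand for lower toxicity in this test and lower numbers for higher toxicity in this test
compound 2 `O=C(CSc1nccn1-c1cccc2ccccc12)Nc1ccccc1Br` gives 30500 nM in this assay

Among the measured compounds shown here, of the two numbers so far, compound 2 has the lower one; compound 1 has the higher, and the gap between them lies beyond the scatter. Compound 3 `O=C(CSc1nccn1-c1cccc2ccccc12)Nc1ccccc1[N+](=O)[O-]` follows from compound 2 by one change: nitro in place of bromo on an aromatic carbon. For the measured compounds named here, no measured pair shows this change, so no step size can be read from the data. The step is expected to stay within the scatter, with no clear direction: the estimated step is a 1.0-fold lower number from compound 2 to compound 3 (0.01 log units; within the scatter). For compound 3 the estimate in this assay is 30000 nM, with a range from 10000 nM to 90000 nM.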

Compound 3, half-maximal cytotoxic concentration: 28800 nM
Compound 3: the middle estimate sits 1.0-fold (0.02 log units) above what was measured; the measured number falls inside the stated range.
By their numbers in this assay, from the lowest: compounds 3 and 2 (each within the scatter of the next); then compound 1.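

In this assay, the first pair differing in one place gives a 1.1-fold lower number from compound 2 to compound 3 (0.02 log units; within the scatter) on going from 2-bromophenyl to 2-nitrophenyl. At this aromatic carbon, ortho to a large group, bromo and nitro therefore read alike in this test, although nitro brings more heavy atoms and adds hydrogen-bond acceptors. No measurement at hand bears on why the two groups read alike. As far as these compounds go, how an amine, a carboxylic acid or a longer chain would read at this carbon stays open. Compound 1 differs from both others in more than one place and gives no readable step.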